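Hydroxymethylpropyl Amide in Place of Methoxyethyl on the Core

A few compounds are considered here, and "the series" means these few. Any claim that something is new, unique, unknown or untested is made for them only; others in the source may bear on it.

Measured compounds:
compound 1 `COCCNC(=O)c1cc2cccc(OC)c2oc1=O`: 18%
compound 2 `COc1cccc2cc(C(=O)Nc3c(C#N)ncn3-c3ccc(C#N)cc3)c(=N)oc12`: 10%
compound 3 `COCCNC(=O)c1cc2cc(Cl)ccc2oc1=N`: 9%

All three were tested in an assay on HEK293 cells for displacement of a labelled ligand from adenosine receptor A2b (Homo sapiens), read by scintillation counting, with a stated time of 30 min, tested at 10 uM; on this read-out lower numbers stand for less inhibition and higher numbers for more inhibition at the one concentration tested (going by the name of the read-out). Compound 3 gives 9%, the lowest of the three numbers, but its gap to compound 2 and its gap to compound 1 both lie within the usual scatter of the measurement, so the three cannot be ranked against each other. For the measured compounds named here, no pair of measured compounds differs in only one place, so there is no single-point step on record to set the size of what a change on the amide-type nitrogen does.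

Compound 4 `CCC(CO)NC(=O)c1cc2cc(Cl)ccc2oc1=N` keeps the core of compound 3 and changes only the substituent on the amide-type nitrogen: 1-(hydroxymethyl)propyl in place of 2-methoxyethyl on an amide-type nitrogen. Going by the values given here, with no calibrating step available, the expectation rests on compound 3 alone. The step from compound 3 to compound 4 in this assay is expected to be small, a number 3 percentage points higher from compound 3 to compound 4 (within the scatter), and not to move beyond the scatter in either direction. Compound 4 is therefore estimated at 12%, with a range from 0% to 28%.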

Compound 4, a percentage reported as inhibition, at one concentration (the size of the read-out at that concentration, not a potency): 9%
For compound 4 the middle estimate is 3 percentage points above the measured one; low and high end bracket the measured number.
By their numbers in this assay, from the lowest: compounds 3, 4, 2 and 1 (each within the scatter of the next).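

In this assay, for the compounds shown here, 1-(hydroxymethyl)propyl in place of 2-methoxyethyl on the amide-type nitrogen gives no change at the digits printed from compound 3 to compound 4 (within the scatter), and this is the first step on record that isolates a change at this position. The entering group has one more heavy atom than the leaving group and one hydrogen-bond donor where the leaving group has none, yet on this core neither difference shows up in the read-out, so the number stays level across this particular exchange. Nothing on hand offers an explanation for this outcome, and it remains a single pair on a single core.

Going by these compounds, whether an amine, a carboxylic acid or a longer chain on the same nitrogen would carry the number beyond the usual scatter remains open, since both groups compared here are short open chains with one oxygen. On these data alone, it also remains open whether the same exchange would read the same way on the core of compound 1 or with the larger nitrogen substituent of compound 2.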